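Ethyl in Place of Bromo on a Shared Core

The compounds below may be only part of what the source reports. "The series", "measured", "known", "first", "only" and "open" are said of these compounds alone.

Compound 1, `CCCCCn1c(N)nc2c(C)cccc21`: 1130 nM
Compound 2, `CCCCCn1c(N)nc2c(Cl)cccc21`: "not active" (no number reported)
Compound 3, `CCCCCn1c(N)nc2c(Br)cccc21`: "not active" (no number reported)

In an assay on HEK293 cells for agonist activity at Toll-like receptor 8 (Homo sapiens), read by reporter gene assay (on this read-out lower numbers stand for an effect already at smaller amounts and higher numbers for an effect only at larger amounts of compound), compound 1 gives 1130 nM. Compound 2 and compound 3 carry a halogen where compound 1 carries a methyl. For compound 3 this assay reports "not active" (no number reported) and no number, and the same holds for compound 2. Compound 3 thus stands without a measurable effect in this assay. Compound 4, `CCCCCn1c(N)nc2c(CC)cccc21`, differs from compound 3 by ethyl in place of bromo on an aromatic carbon. An ethyl is a short chain of carbon like the methyl of compound 1 rather than a halogen, so a measurable effect is expected for compound 4, a step away from compound 3 whose size cannot be counted. The nearest guide is compound 1 with 1130 nM. Compound 4 is expected at 2500 nM, between 600 nM and 15000 nM.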

Compound 4, half-maximal effective concentration: 1650 nM
Beside the measured number, compound 4's estimate is 1.5-fold (0.18 log units) above it, within the range that was stated.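

Swapping in methyl in place of hydrogen on a saturated chain carbon bound to an aromatic carbon gives, in this assay, a 1.5-fold higher number from compound 1 to compound 4 (0.16 log units; within the scatter), so this position takes ethyl as readily as methyl. Among the four compounds, both carbon groups give a number and both halogens, chloro and bromo, give none, so the steps involving those two halogen compounds cannot be read. Nothing at hand offers a reason for this split.

Going by these compounds, whether a longer chain such as butyl still gives a measurable effect here stays open. So does the outcome for an amine or a methoxy group at this place.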